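From chloro to methoxy: estimating the toxicity of compound 4

The source may hold more compounds than are shown below. What is called first, only, known or untested is meant among the compounds shown, and "the series" means these compounds.

Compound 1 `CCN(CC)CN1C(=O)/C(=N/NC(=S)Nc2ccccc2)c2cc(Cl)ccc21`: 3000 nM
Compound 2 `CCN(CC)CN1C(=O)/C(=N/NC(=S)Nc2ccc(Cl)cc2)c2ccccc21`: 400 nM
Compound 3 `CCN(CC)CN1C(=O)/C(=N/NC(N)=S)c2cc(Cl)ccc21`: 78300 nM

All three numbers come from an ADME assay on MDCK cells (Canis lupus familiaris) for cytotoxicity; on this read-out higher numbers stand for lower toxicity in this test and lower numbers for higher toxicity in this test. Compound 2 has the lowest number of the three, so it is the most toxic in this test. Compound 4 `CCN(CC)CN1C(=O)/C(=N/NC(=S)Nc2ccc(OC)cc2)c2ccccc21` differs from it in one place: methoxy in place of chloro on an aromatic carbon. Among the measured compounds shown here, the only measured step, a 26-fold higher number from compound 1 to compound 3 (1.42 log units; beyond the scatter), puts hydrogen in place of phenyl on an amide-type nitrogen. That is a far larger change, so it offers little guidance here. With compound 2 at the bottom at 400 nM, a modest rise seems likelier than a fall, and the estimated step is a 2.0-fold higher number from compound 2 to compound 4 (0.30 log units; within the scatter). For compound 4 the expected value is 800 nM, with an estimated range of 200 nM to 4000 nM.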

Compound 4, half-maximal cytotoxic concentration: 9200 nM
For compound 4 the middle estimate is 12-fold (1.06 log units) below the measured one; measured number outside the range, above it.
By their numbers in this assay, from the lowest: compound 2; then compound 1; then compound 4; then compound 3.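

In this assay, the swap from 4-chlorophenyl to 4-methoxyphenyl gives a 23-fold higher number from compound 2 to compound 4 (1.36 log units; beyond the scatter). The earlier step replaced a whole phenyl with hydrogen, whereas here the ring stays and exchanging one small group on an aromatic carbon, para to a large group, is enough to move the read-out well beyond the scatter. Nothing measured here accounts for the size of this change. On these data alone, whether a fluoro, a methyl or an amino group at this position would fall nearer compound 2 or compound 4 remains open.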